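Same atoms, rearranged rings: estimating the stability of compound 4

This account rests on a few compounds, and the source may have more. Where it says the series, first, only, none or still open, it means among the compounds named here.

In an ADME assay on microsomes from liver (Homo sapiens) for metabolic stability, read by LC-MS, with a stated time of 30 min, tested at 1 uM (on this read-out lower numbers stand for a less stable compound and higher numbers for a more stable compound), compound 1 (`O=C(NCc1ccc(S(=O)(=O)N2CCCCC2)cc1)c1cc2cnccc2s1`) gives 15%, compound 2 (`O=C(NCc1ccc(S(=O)(=O)c2ccccc2C(F)(F)F)cc1)c1cc2cnccc2[nH]1`) gives 52% and compound 3 (`O=C(NCc1ccc(S(=O)(=O)N2CCCCC2)cc1)c1cc2ccncc2[nH]1`) gives 50%. Compound 3 therefore sits level with compound 2 within the usual scatter and well clear of compound 1.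

Compound 4 (`O=C(NCc1ccc(S(=O)(=O)N2CCCCC2)cc1)c1ccc2nc[nH]c2c1`) has the same atoms as compound 3, joined differently: a group of 9 heavy atoms (7 carbon, 2 nitrogen; one five-membered aromatic ring with 2 hetero atoms, one six-membered aromatic ring of carbon only) in place of a group of 9 heavy atoms (7 carbon, 2 nitrogen; one five-membered aromatic ring with 1 hetero atom, one six-membered aromatic ring with 1 hetero atom), on a carbonyl carbon. The group that enters is 1H-benzimidazol-6-yl, and the rest of the molecule stays the same.

Within the data shown here, only one measured step changes the group at this place: a number 35 percentage points higher from compound 1 to compound 3 (beyond the scatter). This large step shows that a change on this carbonyl carbon can move the number considerably, but it involved a different pair of groups and gives no direction here. A step beyond the scatter is therefore not expected, although a sizeable move either way remains possible. The expected change is a number 5 percentage points lower from compound 3 to compound 4 (within the scatter). For compound 4, the estimated value in this assay is 45%, with an expected range from 22% to 70%.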

Compound 4, percent of the compound remaining: 53%
Beside the measured number, compound 4's estimate is 8 percentage points below it, and the stated range covers the measured number.
By their numbers in this assay, from the lowest: compound 1; then compounds 3, 2 and 4 (each within the scatter of the next).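

Rearranging the same atoms into 1H-benzimidazol-6-yl on the carbonyl carbon gives a number 3 percentage points higher from compound 3 to compound 4 (within the scatter) in this assay, so this reshuffling of the two rings leaves the number unchanged as far as this assay can tell. The other new step, a number 38 percentage points higher from compound 1 to compound 4 (beyond the scatter), shows that a second group without sulfur also stands well clear of compound 1, and the earlier large step is therefore not tied to a single ring arrangement. Nothing available here explains this behaviour.

Still open, going by these compounds, is how far the number holds when the new group carries a substituent, such as a methyl group or a fluorine atom, or when a single phenyl ring sits on the carbonyl carbon. The compounds shown also cannot say whether the sulfur atom alone sets compound 1 apart.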